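A few compounds are considered here, and "the series" means these few. Any claim that something is new, unique, unknown or untested is made for them only; others in the source may bear on it.

Working notes on the series. Three compounds of the shared core have been run in a functional assay on A549 cells (Homo sapiens) for cytotoxicity, read by MTT assay, with a stated time of 24 h; a lower number here means a stronger inhibitor, a higher number a weaker inhibitor. Compound 1 `C=CC1=C(C(=O)Nc2ccccc2OC)C(c2ccc(F)cc2)OC1` gives > 100000 nM, which is a limit of the assay and not a number. Compound 2 `C=CC1=C(C(=O)Nc2ccc(C)cc2)C(c2ccc(F)cc2)OC1` gives > 100000 nM, again a limit. Compound 3 `C=CC1=C(C(=O)NCc2ccc(C)cc2)C(c2ccc(F)cc2)OC1` gives > 100000 nM, also a limit. The steps a step that the two limits leave unreadable from compound 1 to compound 2, a step that the two limits leave unreadable from compound 1 to compound 3 and a step that the two limits leave unreadable from compound 2 to compound 3 therefore cannot be sized, and the limit of > 100000 nM in this assay, at which 3 of the 3 values shown sit, is all that the measured set shows. Compound 4 `C=CC1=C(C(=O)Nc2ccc(OCC)cc2)C(c2ccc(F)cc2)OC1` differs from compound 2 by ethoxy in place of methyl on an aromatic carbon. For the measured compounds named here, no measured step covers this change, so the only bearing is that every value so far sits at the limit. Compound 4 is expected to give 150000 nM in this assay, within 50000 nM to 500000 nM. The step that the limit leaves unreadable from compound 2 to compound 4 is expected to be none beyond the scatter, most likely another limit.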

Compound 4, half-maximal inhibitory concentration: "not active" (no number reported)
Nothing numeric was reported for compound 4, so the estimate cannot be set against anything.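

For the compounds shown here, with no number reported for compound 4, no step from compound 2 to compound 4 can be read. Still open is whether any change on the shared core gives a readable value in this assay, the only mark so far being: the limit of > 100000 nM in this assay, at which 3 of the 4 values shown sit.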